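Methoxy in place of cyano on an aromatic carbon

The compounds below may be only part of what the source reports. "The series", "measured", "known", "first", "only" and "open" are said of these compounds alone.

Measured in a functional assay on DU-145 cells (Homo sapiens) for antiproliferative activity, read by CCK-8 assay, with a stated time of 72 h; a lower number here means a stronger inhibitor, a higher number a weaker inhibitor
compound 1 `Cc1cc(Nc2cc(N3CCN(C)CC3)nc(Nc3cccc([N+](=O)[O-])c3)n2)n[nH]1` gives 1340 nM
compound 2 `Cc1cc(Nc2cc(N3CCN(C)CC3)nc(Nc3ccc(C#N)cc3)n2)n[nH]1` gives 1270 nM

Compound 2 stands at 1270 nM and lies within the scatter of compound 1 at 1340 nM so the two numbers cannot be ranked. The next compound to be tested is compound 3 `COc1ccc(Nc2nc(Nc3cc(C)[nH]n3)cc(N3CCN(C)CC3)n2)cc1` which carries methoxy in place of cyano on an aromatic carbon, para to a large group. Its difference from compound 2 reads methoxy in place of cyano on an aromatic carbon and amounts to 4-methoxyphenyl in place of 4-cyanophenyl.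

Going by the values given here, only one measured step bears on this change. That step is a 1.1-fold lower number from compound 1 to compound 2 (0.02 log units; within the scatter) and it came with 4-cyanophenyl in place of 3-nitrophenyl. Among the compounds with values here, it is an indirect guide, as no measured compound carries methoxy. With compound 2 as the starting point, no change beyond the scatter is expected in this assay and no firm direction can be given. The estimated step is a 1.0-fold lower number from compound 2 to compound 3 (0.01 log units; within the scatter) and it remains an expectation. For compound 3 the estimated value is 1250 nM with an expected range from 500 nM to 3000 nM in this estimate.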

Compound 3, half-maximal inhibitory concentration: 5050 nM
The estimate for compound 3 lay 4.0-fold (0.61 log units) below the measured number; the whole stated range lies below it.
By their numbers in this assay, from the lowest: compounds 2 and 1 (each within the scatter of the next); then compound 3.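

The two earlier compounds could not be ranked in this assay, so the substituent on this phenyl ring had not yet been shown to matter; here, a 4.0-fold higher number from compound 2 to compound 3 (0.60 log units; beyond the scatter), with methoxy in place of cyano on an aromatic carbon, para to a large group. Compound 3 also stands apart from the other earlier compound, with a 3.8-fold higher number from compound 1 to compound 3 (0.58 log units; beyond the scatter) on going to 4-methoxyphenyl from 3-nitrophenyl, making it the weakest of the three and showing that this position is sensitive to the exchange, even though cyano and methoxy have the same counts of heavy atoms and hydrogen-bond acceptors. Nothing available gives a reason for this difference.

With only cyano, nitro and methoxy shown on this ring, it remains open whether a hydroxyl, an ethoxy or a primary amine on the same carbon would give a number close to that of compound 2 or close to that of compound 3. From the compounds shown here alone, it is also open whether the same exchange would have a similar effect on a core altered elsewhere.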